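A few compounds are considered here, and "the series" means these few. Any claim that something is new, unique, unknown or untested is made for them only; others in the source may bear on it.

In an ADME assay on HEK-293T cells (Homo sapiens) for inhibition, read by CCK-8 assay, with a stated time of 48 h, tested at 20 uM (on this read-out higher numbers stand for more inhibition of growth at the one concentration tested and lower numbers for less inhibition of growth), compound 1 `COc1ccc(Cc2nnc(NC(=O)/C(C#N)=C/c3ccccc3OS(=O)(=O)c3ccc(C)cc3)s2)cc1` gives 21%, compound 3 `COc1ccc(Cc2nnc(NC(=O)/C(C#N)=C/c3ccccc3OS(=O)(=O)c3ccc(Cl)cc3)s2)cc1` gives 34% and compound 2 `COc1ccc(Cc2nnc(NC(=O)/C(C#N)=C/c3ccccc3OS(=O)(=O)c3ccc([N+](=O)[O-])cc3)s2)cc1` gives 17%. Compound 2 thus sits within the scatter of compound 1 and clearly under compound 3. Compound 4 `Cc1ccc(Cc2nnc(NC(=O)/C(C#N)=C/c3ccccc3OS(=O)(=O)c3ccc([N+](=O)[O-])cc3)s2)cc1` alters compound 2 at another place: methyl in place of methoxy on an aromatic carbon. The measured steps, a number 4 percentage points lower from compound 1 to compound 2 (within the scatter), a number 13 percentage points higher from compound 1 to compound 3 (beyond the scatter) and a number 17 percentage points higher from compound 2 to compound 3 (beyond the scatter), all concern a different substituent, so none tests this change directly. Among the measured compounds shown here, they show only that one swap elsewhere in these molecules moved the number modestly at most. No shift beyond the scatter is therefore expected, and the estimated change is a number 3 percentage points higher from compound 2 to compound 4 (within the scatter). For compound 4 the expected value is 20%, within an estimated range of 8% to 34%.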

Compound 4, percent growth inhibition at one concentration: 9%
Compound 4: middle estimate off by 11 percentage points, on the high side; the measured number falls inside the stated range.
By their numbers in this assay, from the lowest: compounds 4, 2 and 1 (each within the scatter of the next, the first and the last beyond it); then compound 3.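

Among the compounds shown here, this is the first look at the other end of these molecules: putting 4-methylbenzyl in place of 4-methoxybenzyl in this assay gives a number 8 percentage points lower from compound 2 to compound 4 (within the scatter) and so stays inside the usual spread of repeat measurements. In this one pair, with the nitro group in place, methyl can stand in for methoxy without a clear change in growth inhibition. Nothing measured here bears on the reason for so small a step.

On these data alone, whether the swap behaves alike with the chloro group of compound 3 remains open. So does the effect of an amine, a hydroxy group or a longer chain such as ethoxy at this position.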